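The source may hold more compounds than are shown below. What is called first, only, known or untested is meant among the compounds shown, and "the series" means these compounds.

Compound 1 `Cc1ccccc1Nc1nc(C)c(C(=O)/C=C/c2ccc(Cl)cc2)s1` was tested in a functional assay on PC-3 cells (Homo sapiens) for cytotoxicity, read by MTT assay; a higher number here means a weaker inhibitor, a lower number a stronger inhibitor. In this assay compound 1 gives only a limit, > 25000 nM. Compound 2 `Cc1ccccc1Nc1nc(C)c(C(=O)/C=C/c2ccccc2)s1`, which carries hydrogen in place of chloro on an aromatic carbon, gives in this assay likewise only a limit, > 25000 nM. The step from compound 1 to compound 2 is therefore a step that the two limits leave unreadable from compound 1 to compound 2, as the limit of > 25000 nM in this assay, at which 2 of the 2 values shown sit, shows. Compound 3 `Cc1nc(Nc2ccc(Cl)c(Cl)c2)sc1C(=O)/C=C/c1ccc(Cl)cc1` has not yet been measured; it differs from compound 1 by 3,4-dichlorophenyl in place of 2-methylphenyl on a nitrogen on an aromatic ring, the group on that nitrogen being 3,4-dichlorophenyl instead of 2-methylphenyl. For the measured compounds named here, no measured step touches this position, and the one step known is unreadable, so neither a size nor a direction can be drawn from it. For compound 3 the expectation in this assay is a result again sitting at or near the limit, estimated at 30000 nM within 8000 nM to 100000 nM. The step from compound 1 to compound 3 is accordingly expected to be a step that the limit leaves unreadable from compound 1 to compound 3.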

Compound 3, half-maximal inhibitory concentration: > 25000 nM
Compound 3: a limit, no number; the forecaster's own chance of this, stated with the estimate: 75%; the middle value does not contradict the limit.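

Compound 3 gives only a limit in this assay just as compound 1 and compound 2 do, so no step among these three compounds can be read. From the compounds shown here alone, what stays open is whether any change to the shared core would give a real number in this assay rather than another limit.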